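A few compounds are considered here, and "the series" means these few. Any claim that something is new, unique, unknown or untested is made for them only; others in the source may bear on it.

Measured so far in a functional assay for inhibition, with Homo sapiens as the target; a lower number here means that less compound is needed, a higher number that more compound is needed for the effect:

Compound 1, `CC(=O)Nc1ccc(C2=NNC(=O)CC2)cc1`, gives 1 ug/mL.
Compound 2, `CCC(=O)Nc1ccc(C2=NNC(=O)CC2)cc1`, gives 0.64 ug/mL.
Compound 3, `O=C1CCC(c2ccc(NC(=O)CCl)cc2)=NN1`, gives 0.39 ug/mL.

Three compounds share one core and differ only in the group on the saturated chain carbon of the amide. Compound 1 carries the plain acetamido group. Compound 2 carries methyl in place of hydrogen on a saturated chain carbon bound to a carbonyl carbon, and the step of a 1.6-fold lower number from compound 1 to compound 2 (0.19 log units; within the scatter). Compound 3 carries chloro in place of hydrogen on a saturated chain carbon bound to a carbonyl carbon, and the step of a 2.6-fold lower number from compound 1 to compound 3 (0.41 log units; beyond the scatter). Between compound 2 and compound 3 the step of a 1.6-fold lower number from compound 2 to compound 3 (0.22 log units; within the scatter). Compound 3 holds the lowest of the three numbers in this assay, but only its gap to compound 1 is beyond the scatter.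

Compound 4, `CC(Cl)C(=O)Nc1ccc(C2=NNC(=O)CC2)cc1`, is not yet measured. It differs from compound 3 by methyl in place of hydrogen on a saturated chain carbon bound to a carbonyl carbon and a chlorine atom. This is the same kind of change as from compound 1 to compound 2, but not the same: in compound 4 the carbon that receives the methyl is also bound to a chlorine atom, whereas in compound 2 it is bound to the carbonyl carbon only. Within the data shown here, the one measured instance of this kind of change, a 1.6-fold lower number from compound 1 to compound 2 (0.19 log units; within the scatter), fell within the scatter. Among the measured compounds shown here, the step from compound 3 to compound 4 is therefore expected to be small as well, a 1.3-fold lower number from compound 3 to compound 4 (0.11 log units; within the scatter), and the expectation rests on the single step from compound 1 to compound 2 alone. For compound 4 the estimated value in this assay is 0.3 ug/mL, with a range from 0.12 ug/mL to 0.8 ug/mL.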

Compound 4, half-maximal effective concentration: 0.45 ug/mL
Estimate against measurement, compound 4: 1.5-fold (0.18 log units) below; the measured number falls inside the stated range.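

In this assay the new methyl step reads a 1.2-fold higher number from compound 3 to compound 4 (0.06 log units; within the scatter), and the methyl change carries from the core of compound 1 to the core of compound 3 with no difference that can be told from scatter: the same change on two cores in this assay, a 1.6-fold lower number (0.19 log units; within the scatter) from compound 1 to compound 2 and a 1.2-fold higher number (0.06 log units; within the scatter) from compound 3 to compound 4, 1.8-fold (0.26 log units) apart, within the scatter of two such steps

Chloro in place of hydrogen, now read on the core of compound 2, gives a 1.4-fold lower number from compound 2 to compound 4 (0.15 log units; within the scatter), and this change also stays consistent with its earlier instance on the core of compound 1: the same change on two cores in this assay, a 2.6-fold lower number (0.41 log units; beyond the scatter) from compound 1 to compound 3 and a 1.4-fold lower number (0.15 log units; within the scatter) from compound 2 to compound 4, 1.8-fold (0.26 log units) apart, within the scatter of two such steps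

Among these compounds, the combined replacement of methyl by 1-chloroethyl on the carbonyl carbon gives a 2.2-fold lower number from compound 1 to compound 4 (0.35 log units; beyond the scatter), beyond the scatter, but each change rests on only two small steps, so these pairs show agreement within the noise, not that either change is independent of the core in general, and they cannot show how it would carry for a larger step.

What the compounds shown leave open is whether any other group on this saturated chain carbon, such as an amine, a carboxylic acid or a longer chain, would give a step clearly beyond the scatter in this assay. Also open, as far as these compounds go, is whether the agreement seen with methyl and chloro would hold for such groups, or on a core that differs elsewhere than in this amide chain.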